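The source may hold more compounds than are shown below. What is called first, only, known or untested is meant among the compounds shown, and "the series" means these compounds.

Measured in an in vivo ADME assay on the whole organism (strain Sprague-Dawley) for pharmacokinetics, with Rattus norvegicus as the target, at a dose of 2 mg/kg by the intravenous route; a lower number here means that more of the compound stays in the plasma, a higher number that more of the compound sits outside the plasma:
- compound 1 `N#Cc1cc(Cl)cc(Oc2cc(OCc3noc4nc(-n5ccnc5)ccc34)ccc2Cl)c1`: 2.2 L/kg
- compound 2 `N#Cc1cc(Cl)cc(Oc2cc(OCc3noc4nc(N)ccc34)ccc2Cl)c1`: 44.7 L/kg
- compound 3 `N#Cc1cc(Cl)cc(Oc2cc(OCc3n[nH]c4ncccc34)cc(Cl)c2Cl)c1`: 1.8 L/kg

Compound 2 holds the highest of the three numbers, and both other compounds lie far below it, beyond the scatter. Compound 4 `CNc1ccc2c(COc3ccc(Cl)c(Oc4cc(Cl)cc(C#N)c4)c3)noc2n1` is compound 2 with one change: methyl in place of hydrogen on a nitrogen on an aromatic ring. In words, this is methyl in place of hydrogen on a nitrogen on an aromatic ring, or amino to methylamino.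

Among the compounds with values here, only one measured step bears on this place: a 20-fold higher number from compound 1 to compound 2 (1.31 log units; beyond the scatter), a large step in which amino replaces 1H-imidazol-1-yl on an aromatic carbon. It shows that the group here can matter in this assay, but it does not give the size or direction for adding a methyl. Compound 3 differs from compound 2 in more than one place and adds little here.

Compound 2, at 44.7 L/kg, is the top of a small set, so a modest fall is expected, though not one beyond the scatter. The expected change is a 1.6-fold lower number from compound 2 to compound 4 (0.20 log units; within the scatter). For compound 4 the expected value is 28 L/kg, with an estimated range of 9 L/kg to 60 L/kg.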

Compound 4, volume of distribution: 2 L/kg
Beside the measured number, compound 4's estimate is 14-fold (1.15 log units) above it, outside the stated range (below it).
By their numbers in this assay, from the lowest: compounds 3, 4 and 1 (each within the scatter of the next); then compound 2.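

In this assay the position proves far more sensitive than a single added methyl would suggest: a 22-fold lower number from compound 2 to compound 4 (1.35 log units; beyond the scatter) is a large step, as is a 20-fold higher number from compound 1 to compound 2 (1.31 log units; beyond the scatter) at the same place. With a 1.1-fold lower number from compound 1 to compound 4 (0.04 log units; within the scatter) inside the scatter, methylamino and 1H-imidazol-1-yl are not told apart here, and among the compounds that differ at this place only the unsubstituted amino of compound 2 stands apart. No available evidence accounts for this step.

On these data alone, whether a dimethylamino or an ethylamino group at this place would read like compound 4 or like compound 2 remains open. As far as these compounds go, since compound 2 alone carries the amino group, it is also open whether its high number would hold for that group on other cores.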